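A few compounds are considered here, and "the series" means these few. Any claim that something is new, unique, unknown or untested is made for them only; others in the source may bear on it.

Measured compounds and their values:

Compound 1, `OC1CCCN(c2nc(-c3ccccn3)nc3c2CN(Cc2ccccc2)CC3)C1`: 62.9%
Compound 2, `NC(=O)CN1CCN(c2nc(-c3ccccn3)nc3c2CN(Cc2ccccc2)CC3)CC1`: 57.9%
Compound 3, `CN(C)CCN1CCN(c2nc(-c3ccccn3)nc3c2CN(Cc2ccccc2)CC3)CC1`: 41.3%

In an assay on FRT cells with Cystic fibrosis transmembrane conductance regulator variant F508del (Homo sapiens) as the target, read by fluorescence, with a stated time of 25 min (on this read-out lower numbers stand for smaller maximal responses and higher numbers for larger maximal responses), compound 3 gives the lowest of the three numbers shown. Its nearest neighbour is compound 2: a number 16.6 percentage points lower from compound 2 to compound 3 (beyond the scatter). The furthest is compound 1: a number 21.6 percentage points lower from compound 1 to compound 3 (beyond the scatter). Between the other two compounds the difference is small: a number 5 percentage points lower from compound 1 to compound 2 (within the scatter). All three measured steps therefore change the amine substituent on the shared core, and the two steps that go beyond the scatter both lead to compound 3.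

Compound 4, `CN(C)CCN1CCN(c2nc(-c3ccncc3)nc3c2CN(Cc2ccccc2)CC3)CC1`, has not been measured yet. It differs from compound 3 in one place: pyridin-4-yl in place of pyridin-2-yl on an aromatic carbon. Within the data shown here, none of the measured steps touches this part of the molecule; each of them alters only the amine substituent, while the ring in question stays the same across compounds 1, 2 and 3. Among the measured compounds shown here, there is thus no measured step that bears directly on this change, and the size of the step in this assay cannot be read off from the data. With nothing pointing in either direction, the most reasonable expectation is a step that stays within the usual scatter, with a wide margin of uncertainty. On that basis compound 4 is estimated to give about 41% in this assay, within a range from 25% to 58%. The expected step is a number 0.3 percentage points lower from compound 3 to compound 4 (within the scatter), which is expected to fall within the scatter.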

Compound 4, largest response reached (Emax), in percent of the reference or control that the assay uses: "not active" (no number reported)
The entry for compound 4 holds no number, and the estimate cannot be compared.
By their numbers in this assay, from the lowest: compound 3; then compounds 2 and 1 (each within the scatter of the next).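

In this assay, among these compounds, compound 4 is reported as not active and carries no number, so no step between compound 3 and compound 4 can be read. The compounds shown leave open how large a change pyridin-4-yl in place of pyridin-2-yl makes on this read-out. Nothing measured here accounts for the result.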